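Aortic calcium channel series: removing the benzylic amine substituent

A few compounds are considered here, and "the series" means these few. Any claim that something is new, unique, unknown or untested is made for them only; others in the source may bear on it.

compound 1 `COc1cc2c(cc1OC)CN(CCCN1C(=O)CSC1c1cc(C(C)(C)C)c(O)c(C(C)(C)C)c1)CC2`: 200 nM
compound 2 `CN(CCCN1C(=O)CSC1c1cc(C(C)(C)C)c(O)c(C(C)(C)C)c1)Cc1ccccc1`: 600 nM
compound 3 `CN(CCCN1C(=O)CSC1c1cc(C(C)(C)C)c(O)c(C(C)(C)C)c1)CC(O)COc1ccccc1`: 420 nM

In a functional assay on aorta for inhibition of Voltage-dependent L-type calcium channel subunit alpha-1C (Rattus norvegicus) (a lower number here means a stronger inhibitor, a higher number a weaker inhibitor), compound 2 gives 600 nM, the highest of the three numbers. For the measured compounds named here, the only single-point step, a 1.4-fold lower number from compound 2 to compound 3 (0.15 log units; within the scatter), stays within the scatter; compound 1 stands furthest from compound 2, beyond the scatter. Compound 4 `CC(C)(C)c1cc(C2SCC(=O)N2CCCN)cc(C(C)(C)C)c1O` differs from compound 2 by amino in place of benzyl(methyl)amino on a saturated chain carbon, three bonds along the chain from an amide-type nitrogen in a ring. Going by the values given here, the measured step merely swaps what hangs on the amine nitrogen, whereas here the whole benzyl(methyl)amino group goes and a bare amino remains; no measured pair covers such a removal, so the expectation rests on little. For compound 4 a weaker number is expected, a 3.3-fold higher number from compound 2 to compound 4 (0.52 log units; beyond the scatter), with wide uncertainty. The estimate for compound 4 in this assay is 2000 nM, ranging from 600 nM to 7000 nM.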

Compound 4, half-maximal inhibitory concentration: 4400 nM
Compound 4: middle estimate off by 2.2-fold (0.34 log units), on the low side; the measured number falls inside the stated range.
By their numbers in this assay, from the lowest: compound 1; then compounds 3 and 2 (each within the scatter of the next); then compound 4.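

In this assay the position is not indifferent to its substituent: cutting benzyl(methyl)amino back to a bare amino gives (a 7.3-fold higher number from compound 2 to compound 4 (0.87 log units; beyond the scatter)), whereas the swap on the amine nitrogen gave only (a 1.4-fold lower number from compound 2 to compound 3 (0.15 log units; within the scatter)). The substituted amine end therefore matters for inhibition in this pair, although a single removal does not show which part of it counts. No measured evidence bears on the origin of this loss.

The compounds shown leave open whether the benzyl or the methyl carries the difference, which a benzylamino or dimethylamino end would separate. Also open, on these data alone, is whether a longer chain bearing the bare amino behaves the same way.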